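Working notes: piperidin-1-yl to 2-methylpiperidin-1-yl

The source may hold more compounds than are shown below. What is called first, only, known or untested is meant among the compounds shown, and "the series" means these compounds.

Measured in an ADME assay on MT4 cells (Homo sapiens) for cytotoxicity, read by MTT assay, with a stated time of 4 days; on this read-out higher numbers stand for lower toxicity in this test and lower numbers for higher toxicity in this test
- compound 1 (`CCCN(CCC)c1nc(Cc2c(F)cccc2F)c(C)c(=O)[nH]1`) gives > 74000 nM (a limit)
- compound 2 (`Cc1c(Cc2c(F)cccc2F)nc(N2CCCCC2)[nH]c1=O`) gives > 78000 nM (a limit)

Compound 2 is known only as a limit, > 78000 nM. Compound 3 (`Cc1c(Cc2c(F)cccc2F)nc(N2CCCCC2C)[nH]c1=O`) has methyl in place of hydrogen on a saturated ring carbon, next to the ring nitrogen (methyl in place of hydrogen on a saturated ring carbon). Among the compounds with values here, the only measured step, a step that the two limits leave unreadable from compound 1 to compound 2, changes a different group and gives no size. In this assay no step beyond the scatter is expected, and no direction can be assigned. The expected step is an at least 1.0-fold lower number from compound 2 to compound 3 (0.01 log units; that floor lies within the scatter). Compound 3 is estimated at 75000 nM, with an expected range of 35000 nM to 120000 nM.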

Compound 3, half-maximal cytotoxic concentration: 75000 nM
Estimate against measurement, compound 3: no gap at the digits printed, within the range that was stated.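

In this assay, methyl in place of hydrogen on a saturated ring carbon, next to the ring nitrogen, comes with an at least 1.0-fold lower number from compound 2 to compound 3 (0.01 log units; that floor lies within the scatter). That step is only a floor, so the real size of the change at this position may be larger, and compound 3 is the only one of the three with a number rather than a limit. The step from compound 1 to compound 3 cannot be read, and compound 2 stands only as a limit: the limit of > 78000 nM in this assay, at which 1 of the 3 values shown sits.

The compounds shown leave open what an ethyl, a hydroxymethyl or an aminomethyl on this same ring carbon would give in this assay. They also leave open whether a carboxylic acid there would give a number or a limit.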